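Cyclohexyl amine variation in a substance-P antagonist series

The compounds below may be only part of what the source reports. "The series", "measured", "known", "first", "only" and "open" are said of these compounds alone.

Measured so far:
- compound 1, `FC(F)(F)c1cc(COCC2(c3ccccc3)CCC(N3CCCCC3)C2)cc(C(F)(F)F)c1`: 4.7 nM
- compound 2, `CN1CCN(C2CCC(COCc3cc(C(F)(F)F)cc(C(F)(F)F)c3)(c3ccccc3)CC2)CC1`: 120 nM

In an assay on isolated protein for antagonist activity at Substance-P receptor (Homo sapiens) (on this read-out higher numbers stand for weaker inhibition and lower numbers for stronger inhibition), compound 1 gives 4.7 nM and compound 2 gives 120 nM. Compound 2 therefore stands at the higher of the two numbers, the weaker end of what has been measured so far. Within the data shown here, no single-place step connects compound 1 to compound 2; the two differ in more than one respect, so their values are noted side by side without reading a step from them.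

Compound 3, `CCNC1CCC(COCc2cc(C(F)(F)F)cc(C(F)(F)F)c2)(c2ccccc2)CC1`, has not yet been measured in this assay. It differs from compound 2 in one place: ethylamino in place of 4-methylpiperazin-1-yl on a saturated ring carbon. Without a measured step for this kind of exchange, the expectation rests only on where compound 2 stands. A modest move toward lower numbers is expected, of the size a 2.7-fold lower number from compound 2 to compound 3 (0.43 log units; beyond the scatter), though a result within the usual scatter would not be surprising. The estimate for compound 3 in this assay is 45 nM, with a range from 9 nM to 220 nM.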

Compound 3, half-maximal inhibitory concentration: 14 nM
Estimate against measurement, compound 3: 3.2-fold (0.51 log units) above; measured number inside the range.
By their numbers in this assay, from the lowest: compound 1; then compound 3; then compound 2.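

In this assay the group on this saturated ring carbon now has a measured effect of its own, with an 8.6-fold lower number from compound 2 to compound 3 (0.93 log units; beyond the scatter) on exchanging 4-methylpiperazin-1-yl for ethylamino. The series therefore accepts a group of 3 heavy atoms with no ring at this position, and here that group gives the lower number. The exchange alters several things at once, since the six-membered non-aromatic ring with 2 hetero atoms leaves, the heavy-atom count falls from 7 to 3, and the hydrogen-bond donor count rises from 0 to 1; no available evidence accounts for the step.

As far as these compounds go, this single step cannot separate those differences, so it remains open whether the ring, the size of the group or the donor tracks with the lower number. Dimethylamino on the same ring carbon would keep a small group with no ring but carry no hydrogen on the nitrogen, while a longer chain such as n-butylamino would show whether the number holds as the group grows without a ring.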